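This account rests on a few compounds, and the source may have more. Where it says the series, first, only, none or still open, it means among the compounds named here.

Measured in an ADME assay on TZM cells (Homo sapiens) for cytotoxicity, with a stated time of 1 days; a higher number here means that more compound is tolerated, a lower number that less compound is tolerated:
Compound 1 `Cc1cc(C#N)cc(C)c1Oc1nc(Nc2ccc(C#N)cc2)ncc1/C=C/C(=O)NC1CCN(S(C)(=O)=O)CC1`: > 175 nM (a limit)
Compound 2 `Cc1cc(C#N)cc(C)c1Oc1nc(Nc2ccc(C#N)cc2)ncc1/C=C/C(=O)NC1CCN(S(C)(=O)=O)C1`: > 179 nM (a limit)

Compound 2 stands only at a limit, > 179 nM, and no number is known for it. Among the measured compounds shown here, the one measured step is a step that the two limits leave unreadable from compound 1 to compound 2, so it offers no size to carry forward.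

Compound 3 `Cc1cc(C#N)cc(C)c1Oc1nc(Nc2ccc(C#N)cc2)ncc1/C=C/C(=O)N1CCN(C(=O)C(F)(F)F)CC1` departs from compound 2 on a carbonyl carbon, where 4-((trifluoromethyl)carbonyl)piperazin-1-yl takes the place of (1-(methylsulfonyl)pyrrolidin-3-yl)amino: 4-((trifluoromethyl)carbonyl)piperazin-1-yl in place of (1-(methylsulfonyl)pyrrolidin-3-yl)amino on a carbonyl carbon. For the measured compounds named here, no measured step covers this change. The only anchor is therefore the limit for compound 2, > 179 nM, and no step beyond the scatter is expected in this assay. The expected step is a step that the limit leaves unreadable from compound 2 to compound 3. Compound 3 is estimated at 200 nM, with an expected range of 120 nM to 1500 nM, and its result may well again be only a limit.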

Compound 3, half-maximal cytotoxic concentration: > 174 nM
Compound 3 was reported as a limit; the forecaster's own chance of this, stated with the estimate: 85%; the middle value lies beyond the limit too.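

Compound 1, compound 2 and compound 3 are all reported only as limits in this assay, so the steps among them cannot be read. The compounds shown leave open where each true half-maximal cytotoxic concentration lies, and whether changing the group on the carbonyl carbon shifts it.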